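A few compounds are considered here, and "the series" means these few. Any claim that something is new, unique, unknown or untested is made for them only; others in the source may bear on it.

Measured compounds:
Compound 1 `C=CC(=O)NCc1coc(-c2c(N)ncnc2Nc2ccc(Oc3ccccc3)c(Cl)c2)n1` — in an in vitro ADME assay on microsomes from liver (Canis lupus familiaris) for metabolic stability, tested at 5 uM (on this read-out higher numbers stand for a longer-lived compound and lower numbers for a shorter-lived compound), compound 1 is reported only as the limit > 1.66 h.
Compound 2 `C=CC(=O)NCc1coc(-c2c(N)ncnc2Nc2ccc(Oc3ccc(F)cc3)c(Cl)c2)n1` — in this assay compound 2 is likewise reported only as the limit > 1.66 h.

Compound 2 thus stands at a limit of the assay rather than at a number, and that is where every value shown sits: the limit of > 1.66 h in this assay, at which 2 of the 2 values shown sit. Among the compounds with values here, the single measured step, a step that the two limits leave unreadable from compound 1 to compound 2, runs between two values at the same limit and so has no readable size. The next compound, compound 3 `C=CC(=O)NCc1coc(-c2c(N)ncnc2Nc2ccc(Oc3ccccn3)c(Cl)c2)n1`, differs from compound 2 in one place: pyridin-2-yl in place of 4-fluorophenyl on an oxygen on an aromatic ring. No measured step bears directly on this change, and the one step shown offers no size to carry over. What does carry over is that compound 2 sits at the limit, so the expectation for compound 3 is a half-life near or beyond that limit, with the step that the limit leaves unreadable from compound 2 to compound 3 expected to stay within the usual scatter. The estimate for compound 3 in this assay is 1.8 h, expected to fall between 0.8 h and 4 h, with a fair chance that again only a limit is reported.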

Compound 3, half-life: 0.4 h
The estimate for compound 3 lay 4.5-fold (0.65 log units) above the measured number, and the stated range ends above it.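

Replacing 4-fluorophenyl with pyridin-2-yl on the oxygen gives an at least 4.1-fold lower number from compound 2 to compound 3 (0.61 log units; beyond the scatter) in this assay, and replacing phenyl with pyridin-2-yl gives an at least 4.1-fold lower number from compound 1 to compound 3 (0.61 log units; beyond the scatter). Within the data shown here, this position therefore matters for the half-life: the step between the two rings of carbon only could not be read, whereas a ring with one nitrogen gives the first measured number in the set, and a lower one. The true size of both steps could be larger, as the other two compounds are reported only at a limit: the limit of > 1.66 h in this assay, at which 2 of the 3 values shown sit.

The compounds shown cannot tell whether the presence of the ring nitrogen or its place in the ring matters, and a pyridin-3-yl or pyridin-4-yl group on the same oxygen would help separate those two possibilities. Why the half-life is shorter also stays open: nothing shown reports which part of compound 3 is broken down.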